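Swapping an Aromatic Ring for Cyclooctyl on the Amide Nitrogen

The source may report more compounds than this note shows. Statements on the series, on what has been measured and on what is new or still open speak of the compounds shown alone.

Of the compounds shown here, three sharing one core have been tested in an ADME assay on MDBK cells (Bos taurus) for cytotoxicity, read by MTT assay; on this read-out higher numbers stand for lower toxicity in this test and lower numbers for higher toxicity in this test. Compound 1 `CC1CCCCC1N(CCCCCCN1C[C@H](O)[C@@H](O)[C@H](O)[C@H]1CO)C(=O)OC(C)(C)C` gives 250000 nM in this assay. Compound 2 `CC(C)(C)C(=O)N(CCCCCCN1C[C@H](O)[C@@H](O)[C@H](O)[C@H]1CO)c1ccc(F)cc1F` gives > 500000 nM in this assay, which is a limit of the assay and not a number. Compound 3 `CC(=O)N(CCCCCCN1C[C@H](O)[C@@H](O)[C@H](O)[C@H]1CO)c1ccc(F)cc1F` likewise gives > 500000 nM in this assay, again a limit. For the measured compounds named here, the only one-place step, a step that the two limits leave unreadable from compound 2 to compound 3, cannot be sized because the limit of > 500000 nM in this assay, at which 2 of the 3 values shown sit, holds both ends of it. Going by the values given here, compound 2 therefore stands only at a limit, with no measured step from it that can be read.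

Compound 4 `CC(C)(C)C(=O)N(CCCCCCN1C[C@H](O)[C@@H](O)[C@H](O)[C@H]1CO)C1CCCCCCC1` differs from compound 2 by cyclooctyl in place of 2,4-difluorophenyl on an amide-type nitrogen. Among the compounds with values here, no measured step covers such an exchange, and the one step that exists is unreadable, so there is no basis for expecting a change beyond the scatter in this assay. Compound 4 is expected to give 300000 nM, within 100000 nM to 600000 nM. The estimated step is an at least 1.6-fold lower number from compound 2 to compound 4 (0.22 log units; that floor lies within the scatter), with a fair chance that only a limit is reported.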

Compound 4, half-maximal cytotoxic concentration: 270000 nM
The estimate for compound 4 lay 1.1-fold (0.05 log units) above the measured number; low and high end bracket the measured number.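

In this assay, for the compounds shown here, placing cyclooctyl in place of 2,4-difluorophenyl on the amide-type nitrogen gives the first readable step at this position, an at least 1.8-fold lower number from compound 2 to compound 4 (0.26 log units; that floor lies within the scatter). Going by these compounds, only a floor for that step is known, and the true size remains unknown because one end of the step is a limit: the limit of > 500000 nM in this assay, at which 2 of the 4 values shown sit. The floor alone does not establish a change beyond the usual scatter, but compound 4 does provide a measured number for a non-aromatic carbon ring at this position, with the same count of heavy atoms as the aromatic ring it replaces.

The compounds shown leave open how a smaller ring such as cyclopentyl, or a ring carrying an amine or a carboxylic acid, would read at this nitrogen. They also leave open whether cyclooctyl would give a similar reading with the acetyl group of compound 3 on the same nitrogen.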